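The source may hold more compounds than are shown below. What is called first, only, known or untested is meant among the compounds shown, and "the series" means these compounds.

Of the compounds shown here, three built on one shared core have been tested in a functional assay on HEK293 cells for agonist activity at growth hormone secretagogue receptor type 1 (Homo sapiens), read by HTRF and inositol phosphate accumulation, with a stated time of 90 min, in the presence of a further agent that is not named here; a lower number here means a smaller maximal response, a higher number a larger maximal response. Compound 1, `Cc1ccc2[nH]c(C(=O)N[C@H]3CN(S(=O)(=O)c4ccccc4)C[C@H]3C(=O)NCCN(C)C)cc2c1`, gives 72%. Compound 2, `Cc1csc(C(=O)N[C@H]2CN(S(=O)(=O)c3ccccc3)C[C@@H]2C(=O)N[C@H]2CCCNC2)n1`, gives 63%. Compound 3, `Cc1oc(-c2ccc(C(F)(F)F)cc2)nc1C(=O)N[C@H]1CN(S(=O)(=O)c2ccccc2)C[C@@H]1C(=O)N[C@H]1CCCNC1`, gives 85%. Compound 2 stands at the lower end of these three numbers: the gap to compound 1 is within the usual scatter, so the two cannot be told apart, while the gap to compound 3 is beyond it.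

The next compound, compound 4, `O=C(N[C@H]1CN(S(=O)(=O)c2ccccc2)C[C@@H]1C(=O)N[C@H]1CCCNC1)c1cc(-c2ccc(Cl)cc2)on1`, differs from compound 2 in one place: 5-(4-chlorophenyl)-1,2-oxazol-3-yl in place of 4-methyl-1,3-thiazol-2-yl on a carbonyl carbon. Among the compounds with values here, no step between measured compounds tracks this change, so no measured step tells how large its effect is. Among the measured three, compound 3 comes closest in structure to compound 4, and compound 3 gives 85%. On that basis an increase in this assay is expected, a step of a number 17 percentage points higher from compound 2 to compound 4 (beyond the scatter). Compound 4 is therefore estimated to reach 80%, with a likely range from 66% to 92%.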

Compound 4, largest response reached (Emax), in percent of the reference or control that the assay uses: 91%
Estimate against measurement, compound 4: 11 percentage points below, and the stated range covers the measured number.
By their numbers in this assay, from the lowest: compounds 2 and 1 (each within the scatter of the next); then compounds 3 and 4 (each within the scatter of the next).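

On a carbonyl carbon whose other neighbour is an amide-type nitrogen, replacing 4-methyl-1,3-thiazol-2-yl with 5-(4-chlorophenyl)-1,2-oxazol-3-yl in this assay gives a number 28 percentage points higher from compound 2 to compound 4 (beyond the scatter). Within the data shown here, this is the first single change that can be read at this place, and it shows that the maximal response depends on the group that sits there. It also shows that the larger group, which carries an added six-membered aromatic ring of carbon only, goes with a higher response here, not a lower one. No measurement shown here explains the rise.

On these data alone, two things differ in this pair, the five-membered ring and the added 4-chlorophenyl, and their separate shares remain open. Also open, as far as these compounds go, is how the response would change with a plain phenyl or a methyl in place of the 4-chlorophenyl, or with fluorine or methoxy in place of the chlorine.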